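Replacing Cyclobutyl with 2-Cyanophenyl on the Shared Core

The source may report more compounds than this note shows. Statements on the series, on what has been measured and on what is new or still open speak of the compounds shown alone.

Going by the values given here, compound 3 `O=C(O)c1ccccc1-c1ccc(CCc2ncc(CC3CCC3)[nH]2)cc1` gives 7.1 nM in an in vitro functional assay on cells for agonist activity at Bombesin receptor subtype-3 (Mus musculus), read by luminescence and calcium flux (on this read-out higher numbers stand for an effect only at larger amounts of compound and lower numbers for an effect already at smaller amounts), the lowest of the three numbers so far. Compound 1 `O=C(O)c1ccccc1-c1ccc(CCc2ncc(Cc3ccccc3F)[nH]2)cc1` gives 9.5 nM, within the scatter of compound 3, while compound 2 `O=C(O)c1ccccc1-c1ccc(CCc2ncc(CCC3CCCCC3)[nH]2)cc1` gives 33 nM, and the step of a 4.6-fold lower number from compound 2 to compound 3 (0.67 log units; beyond the scatter) lies beyond the scatter. Compound 4 `N#Cc1ccccc1Cc1cnc(CCc2ccc(-c3ccccc3C(=O)O)cc2)[nH]1` differs from compound 3 in one place: 2-cyanophenyl in place of cyclobutyl on a saturated chain carbon bound to an aromatic carbon. Among the compounds with values here, the one measured step that bears on exchanging a four-membered non-aromatic ring for a six-membered aromatic ring at that place is a 1.3-fold lower number from compound 1 to compound 3 (0.13 log units; within the scatter), which stayed within the scatter. Nothing measured tells how 2-cyanophenyl compares with 2-fluorophenyl. For compound 4 the expected step is therefore a 1.3-fold higher number from compound 3 to compound 4 (0.10 log units; within the scatter), nothing beyond the scatter. Compound 4 is estimated at 9 nM, with a range from 3 nM to 30 nM.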

Compound 4, half-maximal effective concentration: 642 nM
Beside the measured number, compound 4's estimate is 71-fold (1.85 log units) below it, outside the stated range (above it).
By their numbers in this assay, from the lowest: compounds 3 and 1 (each within the scatter of the next); then compound 2; then compound 4.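

In this assay, going by these compounds alone, this place proves far less forgiving than the earlier compounds suggested, since cyano in place of fluoro on an aromatic carbon alone gives a 68-fold higher number from compound 1 to compound 4 (1.83 log units; beyond the scatter) and marks the largest change among compounds sharing an aromatic ring here. The non-aromatic groups also compare well, with a 90-fold higher number from compound 3 to compound 4 (1.96 log units; beyond the scatter) and a 19-fold higher number from compound 2 to compound 4 (1.29 log units; beyond the scatter) at this saturated chain carbon, so an aromatic ring here gives a low number with fluoro but not with cyano. Nothing available explains this loss.
As far as these compounds go, whether chloro or methoxy in place of fluoro would behave like fluoro or like cyano remains open.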